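The source may hold more compounds than are shown below. What is called first, only, known or untested is meant among the compounds shown, and "the series" means these compounds.

Measured compounds:
- compound 1, `O=C(Nc1cccc(-n2cc(-c3ccncc3)c(-c3cc(O)cc(Cl)c3)n2)c1)Nc1ccc(Cl)c(C(F)(F)F)c1`: -38%
- compound 2, `O=C(Nc1cccc(-n2cc(-c3ccncc3)c(-c3cc(O)cc(Cl)c3)n2)c1)Nc1ccc(Cl)c(Cl)c1`: -41%
- compound 3, `COc1cc(Cl)cc(-c2nn(-c3cccc(NC(=O)Nc4cc(C(F)(F)F)cc(C(F)(F)F)c4)c3)cc2-c2ccncc2)c1`: -47%

These three compounds share one core and differ only in the groups on the outer phenyl of the urea. In a functional assay on NCI-H226 cells (Homo sapiens) for inhibition, read by sulforhodamine B assay, with a stated time of 48 h, tested at 100 uM (on this read-out lower numbers stand for a stronger effect and higher numbers for a weaker effect at the one concentration tested), compound 3 gives the lowest of the three numbers, yet its distances to compound 2 and to compound 1 both lie within the usual scatter, so the three compounds cannot be told apart on these numbers.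

Compound 4, `COc1cc(Cl)cc(-c2nn(-c3cccc(NC(=O)Nc4cccc(C(F)(F)F)c4)c3)cc2-c2ccncc2)c1`, is built from compound 3 by one change: hydrogen in place of trifluoromethyl on an aromatic carbon. Among the measured compounds shown here, the only measured step, a number 3 percentage points lower from compound 1 to compound 2 (within the scatter), swapped one group for another of similar size and stayed within the scatter. For the measured compounds named here, no measured step removes a trifluoromethyl group altogether, so the nearest guide is that exchanges on this phenyl have so far moved little. A step of a number 9 percentage points higher from compound 3 to compound 4 (within the scatter) is therefore expected in this assay, with no change beyond the scatter as the likeliest outcome. Compound 4 is estimated to give -38%, within the range -65% to 0%.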

Compound 4, a percentage reported as activity, at one concentration (the size of the read-out at that concentration, not a potency): -22%
Compound 4: middle estimate off by 16 percentage points, on the low side; low and high end bracket the measured number.
By their numbers in this assay, from the lowest: compounds 3, 2 and 1 (each within the scatter of the next); then compound 4.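

In this assay, replacing one trifluoromethyl group with hydrogen gives a number 25 percentage points higher from compound 3 to compound 4 (beyond the scatter), which means a weaker effect at the one concentration tested. Among the compounds shown here, this shows that the read-out responds to a change at this place on the outer phenyl of the urea, something the only earlier step, a number 3 percentage points lower from compound 1 to compound 2 (within the scatter), did not show. Nothing measured here bears on why removing this group has that effect.

The compounds shown leave open whether a different group at this place, such as a methyl, an amine or a carboxylic acid, would keep the number close to that of compound 3 or move it towards that of compound 4. They also leave open whether the same removal would give a step of similar size in a compound with the hydroxyl of compound 1.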